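The source may report more compounds than this note shows. Statements on the series, on what has been measured and on what is new or still open speak of the compounds shown alone.

Measured so far in an ADME assay on PC-3 cells (Homo sapiens) for cytotoxicity, read by WST assay, tested at 100 uM; on this read-out higher numbers stand for more inhibition at the one concentration tested (going by the name of the read-out) and lower numbers for less inhibition:

- compound 1 `Cc1cccc(C(=O)N2CCCC(C(=O)Nc3ccc(Cl)cc3)C2)c1`: 0%
- compound 2 `CSc1cccc(NC(=O)C2CCCN(C(=O)c3cc(C(F)(F)F)cc(C(F)(F)F)c3)C2)c1`: 0%
- compound 3 `Cc1nc(-c2cccc(C(=O)N3CCCC(C(=O)Nc4ccc(Cl)cc4)C3)c2)no1`: 0%

All three measured compounds share a core and show no measurable effect on the cells at the single concentration used. Compound 3 stands level with compound 1 and with compound 2 at the digits shown, and the one step that has been measured, no change at the digits printed from compound 1 to compound 3 (within the scatter), brought 5-methyl-1,2,4-oxadiazol-3-yl in place of methyl on an aromatic carbon without moving the read-out beyond the scatter.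

Compound 4 `CS(=O)(=O)Nc1cccc(C(=O)N2CCCC(C(=O)Nc3ccc(Cl)cc3)C2)c1` keeps the same core and differs from compound 3 only in one group: methanesulfonamido in place of 5-methyl-1,2,4-oxadiazol-3-yl on an aromatic carbon. The change sits on an aromatic carbon of a six-membered aromatic ring of carbon only, meta to a large group, the same position that was varied between compound 1 and compound 3. That earlier step bears directly on this one, and it showed no change within the scatter. Among the measured compounds shown here, nothing among the measured compounds points to any group at this position raising the read-out in this assay, so the expected step from compound 3 to compound 4 is no change at the digits printed from compound 3 to compound 4 (within the scatter), none beyond the scatter. Compound 4 is therefore estimated to give 0% in this assay, with a range of -10% to 12%.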

Compound 4, a percentage reported as inhibition, at one concentration (the size of the read-out at that concentration, not a potency): 3%
Estimate against measurement, compound 4: 3 percentage points below; the range from low to high includes it.
By their numbers in this assay, from the lowest: compounds 1, 2, 3 and 4 (each within the scatter of the next).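

In this assay, replacing a five-membered aromatic ring with an open group gives a number 3 percentage points higher from compound 3 to compound 4 (within the scatter) and so stays inside the usual spread of repeat measurements. The comparison with the smallest group at this position gives a number 3 percentage points higher from compound 1 to compound 4 (within the scatter) and likewise stays inside that spread, even though methanesulfonamido brings a hydrogen-bond donor that 5-methyl-1,2,4-oxadiazol-3-yl lacks. Methyl, 5-methyl-1,2,4-oxadiazol-3-yl and methanesulfonamido therefore cannot be told apart at this aromatic carbon in this read-out, and no measurement on hand offers an explanation for that.

The compounds shown leave open whether an amine or a carboxylic acid on this aromatic carbon, or a longer chain in place of the methanesulfonamido group, would give a number beyond the scatter. They also leave open whether a change elsewhere on the shared core, such as replacing the chlorine on the other aromatic ring with a hydroxyl group while keeping the rest of compound 4, would move the read-out at all.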